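The source may hold more compounds than are shown below. What is called first, only, known or untested is meant among the compounds shown, and "the series" means these compounds.

Measured so far:

Compound 1, `C=C(Br)C(=O)Nc1cccc(/C=C/C(=O)Nc2ccccc2)c1`, in a functional assay on HeLa cells (Homo sapiens) for inhibition, read by MTT assay, with a stated time of 72 h (a higher number here means a weaker inhibitor, a lower number a stronger inhibitor), gives 7300 nM.
Compound 2, `C=C(Br)C(=O)Nc1cccc(/C=C/C(=O)Nc2ccc(OC)cc2)c1`, in this assay gives 790 nM.
Compound 3, `C=C(Br)C(=O)Nc1cccc(/C=C/C(=O)Nc2cc(OC)cc(OC)c2)c1`, in this assay gives 2200 nM.

All three share one core and differ only in the groups on the outer phenyl ring of the second amide. Among the compounds with values here, the single measured step is methoxy in place of hydrogen on an aromatic carbon; it lowers the number, with a 9.2-fold lower number from compound 1 to compound 2 (0.97 log units; beyond the scatter). Compound 3, which carries two methoxy groups on that ring, sits between the other two: its value is beyond the scatter from both compound 2 and compound 1. How compound 3 differs from compound 1 is not broken down here.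

Compound 4, `C=C(Br)C(=O)Nc1cccc(/C=C/C(=O)Nc2cc(OC)c(OC)c(OC)c2)c1`, is not yet measured. It differs from compound 3 by methoxy in place of hydrogen on an aromatic carbon. Within the data shown here, this is the same kind of change as the one from compound 1 to compound 2, though not the same: the new methoxy in compound 4 sits ortho to two methoxy groups as well as para to a large group, whereas in compound 2 it sits only para to a large group. Adding a methoxy at the position para to a large group was what helped in the measured pair, so in this assay compound 4 is expected to show a step of a 2.4-fold lower number from compound 3 to compound 4 (0.39 log units; beyond the scatter) relative to compound 3, smaller than the earlier step. Among the measured compounds shown here, a methoxy entering ortho to two methoxy groups has no measured precedent here. The estimate for compound 4 is 900 nM, expected to fall between 250 nM and 3000 nM.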

Compound 4, half-maximal inhibitory concentration: 880 nM
The estimate for compound 4 lay 1.0-fold (0.01 log units) above the measured number, and the stated range covers the measured number.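

Putting a methoxy in place of hydrogen on an aromatic carbon lowers the number in both measured cases in this assay. The new case is a 2.5-fold lower number from compound 3 to compound 4 (0.40 log units; beyond the scatter), so the direction of the change holds on a ring that already carries two methoxy groups, as it did on the bare phenyl ring of compound 1. Within the data shown here, the size of the step does not carry over, and the gap between the two cases is larger than repeat measurements would explain: the same change on two cores in this assay, a 9.2-fold lower number (0.97 log units; beyond the scatter) from compound 1 to compound 2 and a 2.5-fold lower number (0.40 log units; beyond the scatter) from compound 3 to compound 4, 3.7-fold (0.57 log units) apart, beyond the scatter of two such steps With only two pairs, the data do not show why the second step is smaller, since the new methoxy in compound 4 sits ortho to two methoxy groups as well as para to a large group, while the one in compound 2 sits only para to a large group, and they cannot predict the step on any further core.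

The compounds shown leave open how a group other than methoxy, such as a hydroxyl, a fluorine or an amine, would behave at the same place on this ring. They also leave open what happens when the bromine of the shared core gives way to hydrogen or chlorine.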